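The source may report more compounds than this note shows. Statements on the series, on what has been measured and on what is new or still open speak of the compounds shown alone.

Measured in an ADME assay on HepG2 cells (Homo sapiens) for cytotoxicity, read by luminescence, with a stated time of 72 h; a higher number here means that more compound is needed for the effect, a lower number that less compound is needed:
- Compound 1 `CCOC(=O)c1c(-c2cccc(OC)c2)[nH]c2cc(OC)ccc2c1=O`: > 21500 nM
- Compound 2 `CCOC(=O)c1c(-c2cccc(Br)c2)[nH]c2cc(OC)ccc2c1=O`: > 21500 nM
- Compound 3 `CCOC(=O)c1c(-c2cccc(CO)c2)[nH]c2cc(OC)ccc2c1=O`: > 21500 nM

Each of these entries is a limit of the assay and not a number. Compound 1 therefore has no exact position on the scale: its > 21500 nM is a limit. The same holds across the set: the limit of > 21500 nM in this assay, at which 3 of the 3 values shown sit.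

Compound 4 `CCOC(=O)c1c(-c2cccc(OC)c2)[nH]c2cc(C(F)(F)F)ccc2c1=O` keeps the core of compound 1 but carries trifluoromethyl in place of methoxy on an aromatic carbon of the ring that is part of a fused system (trifluoromethyl in place of methoxy on an aromatic carbon).

Among the compounds with values here, two measured steps bear on this change, since each replaces the other methoxy of compound 1: a step that the two limits leave unreadable from compound 1 to compound 2, and a step that the two limits leave unreadable from compound 1 to compound 3. Neither has a size that can be read, and neither was made at the place that changes in compound 4. They give no sign of a change in either direction, so no step beyond the usual scatter is expected, and another limit is likely.

The estimate is an expected a number no higher from compound 1 to compound 4 (the limit leaves the size open). For compound 4 the expected value is 21500 nM, with an estimated range from 10000 nM to 40000 nM.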

Compound 4, half-maximal effective concentration: > 21500 nM
Compound 4 was reported as a limit; the forecaster's own chance of this, stated with the estimate: 80%; the middle value lies on the limit itself.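

Within the data shown here, compound 4 gives > 21500 nM, which is a limit of the assay and not a number, so no step from compound 1 to compound 4 can be read. The compounds shown leave open how much of any of them is needed for the effect in this assay: the limit of > 21500 nM in this assay, at which 4 of the 4 values shown sit.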